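The source may hold more compounds than are shown below. What is called first, only, known or untested is meant among the compounds shown, and "the series" means these compounds.

The measured compounds:

compound 1, `CS(=O)(=O)c1ccc(-n2nc(C(F)(F)F)cc2-c2ccccc2)nc1`, 50 ug/mL
compound 2, `CS(=O)(=O)c1ccc(-n2nc(C(F)(F)F)c(C#N)c2-c2ccccc2)nc1`, 100 ug/mL
compound 3, `CC(C)COc1cc(C(F)(F)F)nn1-c1ccc(S(C)(=O)=O)cn1`, 50 ug/mL

All three were measured in a physicochemical assay for solubility; a higher number here means a more soluble compound, a lower number a less soluble compound. Compound 1 and compound 2 share a core; the one difference between them is cyano in place of hydrogen on an aromatic carbon, and that change gave a 2.0-fold higher number from compound 1 to compound 2 (0.30 log units; within the scatter). Compound 3 differs from compound 1 in its core: isobutoxy in place of phenyl on an aromatic carbon, which gave no change at the digits printed from compound 1 to compound 3 (within the scatter). So compound 3 and compound 1 give the same number in this assay, and compound 2 sits within the scatter of both.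

Compound 4, `CC(C)COc1c(C#N)c(C(F)(F)F)nn1-c1ccc(S(C)(=O)=O)cn1`, has not yet been measured in this assay. It differs from compound 3 by cyano in place of hydrogen on an aromatic carbon. Among the compounds with values here, this is the same kind of change as the one from compound 1 to compound 2, but the surroundings are not identical: in compound 1 the carbon that takes the cyano group is next to the ring atom that bears a phenyl group, whereas in compound 3 it is next to the ring atom that bears an isobutoxy group; in both it is next to the ring atom that bears a trifluoromethyl group.

For compound 4 the expected step is a 1.8-fold higher number from compound 3 to compound 4 (0.26 log units; within the scatter). Within the data shown here, this expectation rests on compound 1 and compound 2, because a 2.0-fold higher number from compound 1 to compound 2 (0.30 log units; within the scatter) is the only example of this change available and it lay within the scatter. Compound 4 is therefore estimated at 90 ug/mL, with a likely range from 45 ug/mL to 180 ug/mL.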

Compound 4, solubility: < 25 ug/mL
Compound 4 ended at the assay's limit; the forecaster's own chance of this, stated with the estimate: 5%; at least 3.6-fold (0.55 log units) between middle value and limit.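

In this assay compound 4 gives < 25 ug/mL, which is a limit of the assay and not a number. Cyano in place of hydrogen gave a 2.0-fold higher number from compound 1 to compound 2 (0.30 log units; within the scatter), but the same change on the isobutoxy compound gave an at least 2.0-fold lower number from compound 3 to compound 4 (0.30 log units; that floor lies within the scatter), so the earlier step did not carry over to this core, although this pair alone does not show a drop that clears the scatter and its true size stays unknown. The clearer signal comes from isobutoxy in place of phenyl, which gave no change at the digits printed from compound 1 to compound 3 (within the scatter) without the cyano group but an at least 4.0-fold lower number from compound 2 to compound 4 (0.60 log units; beyond the scatter) with it, showing that among these four compounds the outcome of one change depended on the other, while showing neither a rule for the wider series nor a reason for the result.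

The compounds shown leave open how far past the limit compound 4 really lies, a question that only a measured number could settle. They also leave open how the cyano change would behave with other groups in place of isobutoxy, such as a shorter methoxy group, an amine or a carboxylic acid.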